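The source may report more compounds than this note shows. Statements on the series, on what has been measured and on what is new or still open speak of the compounds shown alone.

Compound 1 `CCOC(=O)/C=N/c1cnc(Nc2ccc(N3CCN(C)CC3)cc2)nc1NC1CCCC1` gives 17000 nM in a functional assay on HCT-116 cells (Homo sapiens) for antiproliferative activity, read by MTT assay; on this read-out lower numbers stand for stronger inhibition and higher numbers for weaker inhibition.
Compound 2 `CN1CCN(c2ccc(Nc3ncc(/N=C/c4ccccc4)c(NC4CCCC4)n3)cc2)CC1` gives 35200 nM in this assay.
Compound 3 `CCOC(=O)/C=N/c1cnc(Nc2ccc(N3CCN(C)CC3)cc2)nc1NC(C)C` gives 13600 nM in this assay.

Compound 3 has the lowest of the three numbers in this assay. Its nearest neighbour is compound 1, a change that is within the scatter, as a 1.3-fold lower number from compound 1 to compound 3 (0.10 log units; within the scatter) shows; compound 2 lies further off, beyond the scatter, so compound 3 and compound 1 cannot be ordered against each other, while both stand apart from compound 2.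

Compound 4 `CC(C)Nc1nc(Nc2ccc(N3CCN(C)CC3)cc2)ncc1/N=C/c1ccccc1` has not yet been measured in this assay. It differs from compound 3 in one place: phenyl in place of ethoxycarbonyl on a carbon with a double bond to nitrogen. The same change has already been seen once, on the cyclopentyl-bearing core: from compound 1 to compound 2 it gave a 2.1-fold higher number from compound 1 to compound 2 (0.32 log units; beyond the scatter), a modest rise, just beyond the scatter. Within the data shown here, no other measured step bears on it. The account therefore expects the step from compound 3 to compound 4 to be of similar size and in the same direction, a modest rise of about a 2.1-fold higher number from compound 3 to compound 4 (0.31 log units; beyond the scatter) in this assay.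

On this basis compound 4 is estimated to give about 28000 nM in this assay, with a range from 14000 nM to 58000 nM.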

Compound 4, half-maximal inhibitory concentration: > 100000 nM
Compound 4 was reported as a limit; the forecaster's own chance of this, stated with the estimate: 5%; at least 3.5-fold (0.55 log units) between middle value and limit.
By their numbers in this assay, from the lowest: compounds 3 and 1 (each within the scatter of the next); then compound 2. At a limit, above all of these: compound 4.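

In this assay compound 4 gives > 100000 nM, which is a limit of the assay and not a number. The change from ethoxycarbonyl to phenyl on a carbon with a double bond to nitrogen therefore has no fixed size: with isopropyl on the other nitrogen it gives an at least 7.3-fold higher number from compound 3 to compound 4 (0.86 log units; beyond the scatter), and the two cores part company: the same change on two cores in this assay, a 2.1-fold higher number (0.32 log units; beyond the scatter) from compound 1 to compound 2 and an at least 7.3-fold higher number (0.86 log units; beyond the scatter) from compound 3 to compound 4, at least 3.5-fold (0.55 log units) apart, beyond the scatter of two such steps The isopropyl-for-cyclopentyl change, which made no difference beyond the scatter while ethoxycarbonyl was present, gives an at least 2.8-fold higher number from compound 2 to compound 4 (0.45 log units; beyond the scatter) when phenyl is present, so the two places do not act independently of each other here: the same change on two cores in this assay, a 1.3-fold lower number (0.10 log units; within the scatter) from compound 1 to compound 3 and an at least 2.8-fold higher number (0.45 log units; beyond the scatter) from compound 2 to compound 4, at least 3.5-fold (0.55 log units) apart, beyond the scatter of two such steps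

Going by these compounds, how far compound 4 lies past the limit stays unknown, so both new steps give only a floor and not a size. The compounds shown also leave open whether the loss follows phenyl in particular or any replacement of ethoxycarbonyl on this carbon, such as a carboxylic acid or a pyridine ring, and whether a cyclopropyl group on the nitrogen would behave like isopropyl or like cyclopentyl.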